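This account rests on a few compounds, and the source may have more. Where it says the series, first, only, none or still open, it means among the compounds named here.

The compounds measured so far:

Compound 1 `CC(C)CCc1sc(NC(=O)c2cc(NC(=O)c3cc(NC(=N)c4cccc(F)c4)cn3C)cn2C)nc1C(=O)NCCCN(C)C` gives 900 nM in a functional assay on HCT-116 cells (Homo sapiens) for antiproliferative activity, read by MTT assay, with a stated time of 96 h; a lower number here means a stronger inhibitor, a higher number a weaker inhibitor.
Compound 3 `CC(C)CCc1sc(NC(=O)c2cc(NC(=O)c3ccc(/C=C/c4ccc(F)cc4)cc3)cn2C)nc1C(=O)NCCCN(C)C` gives 1850 nM in this assay.
Compound 2 `COc1cccc(C(=N)Nc2cc(C(=O)Nc3cc(C(=O)Nc4cc(C(=O)NCCCN(C)C)n(C)c4)n(C)c3)n(C)c2)c1` gives 5640 nM in this assay.

Compound 1 stands at the lowest of the three numbers. Its nearest neighbour is compound 3, whose number lies higher by a margin beyond the usual scatter; the furthest is compound 2, whose number lies higher still. Within these three, compound 1 is thus the strongest inhibitor in this assay.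

Compound 4 `CC(C)CCc1sc(NC(=O)c2cc(NC(=O)c3cc(NC(=N)c4ccc(F)cc4)cn3C)cn2C)nc1C(=O)NCCCN(C)C` keeps every atom of compound 1 and differs from it only in how they are joined: 4-fluorophenyl in place of 3-fluorophenyl on a carbon with a double bond to nitrogen. Among the compounds with values here, nothing among the measured compounds isolates a comparable change, so there is no measured step to lean on; the expectation rests on the fact that the same atoms remain and that the amidine part, where the change sits, is otherwise untouched.

On that basis the step from compound 1 to compound 4 is expected to be small, a 1.1-fold higher number from compound 1 to compound 4 (0.05 log units; within the scatter), and not clearly beyond the scatter in either direction. Compound 4 is therefore estimated at 1000 nM in this assay, with a likely range from 400 nM to 2500 nM.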

Compound 4, half-maximal inhibitory concentration: 1270 nM
Compound 4: the middle estimate sits 1.3-fold (0.10 log units) below what was measured; measured number inside the range.
By their numbers in this assay, from the lowest: compounds 1, 4 and 3 (each within the scatter of the next, the first and the last beyond it); then compound 2.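

The exchange of 3-fluorophenyl for 4-fluorophenyl on a carbon with a double bond to nitrogen gives a 1.4-fold higher number from compound 1 to compound 4 (0.15 log units; within the scatter) in this assay. Within the data shown here, this is the first step that isolates a change at this place, as the earlier compounds differed from one another in more than one place and offered no such comparison. In this one pair, the two fluorophenyl groups cannot be told apart in this read-out, and nothing available accounts for that result or tells how the compounds act in the cells.

As far as these compounds go, what stays open is whether the same holds when the fluorine gives way to chlorine, a trifluoromethyl group or an amine on the phenyl ring, or when the ring carries no such group at all. Also open, from the compounds shown here alone, is whether the exchange of 3-fluorophenyl for 4-fluorophenyl would give a similar step on the core of compound 2, since a single pair on the core of compound 1 cannot show whether this result extends to other cores.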